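The source may hold more compounds than are shown below. What is called first, only, known or untested is meant among the compounds shown, and "the series" means these compounds.

In a functional assay on Jurkat cells (Homo sapiens) for antiproliferative activity, read by MTT assay, with a stated time of 72 h (a higher number here means a weaker inhibitor, a lower number a stronger inhibitor), compound 1 (`CNc1nc(-c2cc(OC)c(OC)c(OC)c2)c(-c2ccc(C(F)(F)F)cc2)s1`) gives 3010 nM and compound 2 (`COc1cc(-c2nc(N(C)C)sc2-c2ccc3ccccc3c2)cc(OC)c1OC`) gives 836 nM as the lower of the two numbers. The gap lies beyond the scatter, which makes compound 2 the stronger inhibitor. Compound 3 (`COc1cc(-c2nc(N(C)C)sc2-c2ccc(C(F)(F)F)cc2)cc(OC)c1OC`) has 4-(trifluoromethyl)phenyl in place of naphthalen-2-yl on an aromatic carbon. Compound 1 carries the same 4-(trifluoromethyl)phenyl and gives 3010 nM on the weaker side. A moderate rise toward weaker inhibition is therefore expected in this assay and is estimated as a 3.6-fold higher number from compound 2 to compound 3 (0.55 log units; beyond the scatter) in size. For compound 3 the expected value is 3000 nM with an estimated range from 900 nM to 10000 nM in this measurement.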

Compound 3, half-maximal inhibitory concentration: > 10000 nM
Compound 3: no number, only a limit; the forecaster's own chance of this, stated with the estimate: 15%; middle value at least 3.3-fold (0.52 log units) from the limit.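

Compound 3 gives only a limit of the assay, not a number: the limit of > 10000 nM in this assay, at which 1 of the 3 values shown sits.

Even so, at this aromatic carbon next to the ring sulfur, 4-(trifluoromethyl)phenyl in place of naphthalen-2-yl gives an at least 11-fold higher number from compound 2 to compound 3 (1.07 log units; beyond the scatter), so the group here strongly shapes the result in this assay. With 4-(trifluoromethyl)phenyl kept, methyl in place of hydrogen on the nitrogen gives an at least 3.3-fold higher number from compound 1 to compound 3 (0.52 log units; beyond the scatter), so that nitrogen matters as well.

As far as these compounds go, how a plain phenyl or a 4-methoxyphenyl would behave at this carbon remains open, as does an unsubstituted amino group on the nitrogen.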